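Notes on the ring-nitrogen substituent and maximal response

The compounds below may be only part of what the source reports. "The series", "measured", "known", "first", "only" and "open" are said of these compounds alone.

In a functional assay on the whole organism (B cells) with Mus musculus as the target (a higher number here means a larger maximal response, a lower number a smaller maximal response), the measured compounds stand as follows:
compound 1 `CCCn1c(=O)n(C2OC(COP(=O)(O)O)[C@@H](O)[C@H]2O)c2nc(N)nc(O)c21` gives 76%
compound 2 `CCCCCCCCCCn1c(=O)n(C2OC(CO)[C@@H](O)[C@H]2O)c2nc(N)nc(O)c21` gives 0%
compound 3 `C=CCn1/c(=N\C#N)n([C@H]2OC(CO)[C@@H](O)[C@H]2O)c2cc(N)nc(O)c21` gives 85%

Compound 2 holds the lowest of the three numbers; compound 1 lies a large distance above it, compound 3 further still, both gaps beyond the scatter. Compound 4 `Nc1nc(O)c2c(n1)n(C1OC(CO)[C@@H](O)[C@H]1O)c(=O)n2Cc1ccccc1` is not yet measured. It differs from compound 2 by phenyl in place of nonyl on a saturated chain carbon bound to an aromatic nitrogen. The shorter substituents of compound 1 and compound 3 sit with high maximal response, while the longest, in compound 2, gives none; benzyl lies between these in size. An upward step beyond the scatter is expected, as a number 50 percentage points higher from compound 2 to compound 4 (beyond the scatter). Compound 4 is estimated at 50%, in the range 10% to 85%.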

Compound 4, largest response reached (reported as maximal response), in percent of the reference or control that the assay uses: 110%
The estimate for compound 4 lay 60 percentage points below the measured number; the measured number lies above the stated range.
By their numbers in this assay, from the lowest: compound 2; then compounds 1 and 3 (each within the scatter of the next); then compound 4.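

In this assay, phenyl in place of nonyl on a saturated chain carbon bound to an aromatic nitrogen gives a number 110 percentage points higher from compound 2 to compound 4 (beyond the scatter) with the rest of the structure unchanged. The shared core of compound 2 therefore does not by itself abolish the response, and this position accepts an aromatic ring with a large maximal response. No measurement here explains the step.

This single pair cannot separate the effect of the ring from that of the chain length. A hexyl chain or a phenethyl group on the same nitrogen would bear on that question.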